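Working notes on a short cytotoxicity series

The source may report more compounds than this note shows. Statements on the series, on what has been measured and on what is new or still open speak of the compounds shown alone.

Measured so far:
compound 1 `FC(F)(F)c1ccc(CSc2nc(Nc3ccccc3C(F)(F)F)c3ccccc3n2)cc1` — > 50000 nM
compound 2 `Fc1ccc(Nc2nc(SCc3ccc(C(F)(F)F)cc3)nc3ccccc23)cc1` — 9620 nM

In a functional assay on MGC-803 cells (Homo sapiens) for cytotoxicity, read by MTT assay, with a stated time of 72 h (on this read-out lower numbers stand for stronger inhibition and higher numbers for weaker inhibition), compound 1 gives only a limit, not a number, (the limit of > 50000 nM in this assay, at which 1 of the 2 values shown sits). Going by the values given here, compound 2 is the one compound with a number in this assay and so stands alone; the step of an at least 5.1-fold lower number from compound 1 to compound 2 (0.71 log units; beyond the scatter) is the only measured one, with 4-fluorophenyl in place of 2-(trifluoromethyl)phenyl on a nitrogen on an aromatic ring.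

Compound 3 `FC(F)(F)c1ccc(CSc2nc(Nc3ccc(Cl)cc3)c3ccccc3n2)cc1` differs from compound 2 by chloro in place of fluoro on an aromatic carbon. The measured step of an at least 5.1-fold lower number from compound 1 to compound 2 (0.71 log units; beyond the scatter) exchanges the whole aryl group and does not repeat this single substituent change, so it bears only loosely on the step to compound 3. A change within the scatter, or a small one in either direction, is expected. Compound 3 is estimated at 7000 nM, with a range of 2500 nM to 25000 nM, which is expected to mean a 1.4-fold lower number from compound 2 to compound 3 (0.14 log units; within the scatter) in this assay.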

Compound 3, half-maximal inhibitory concentration: 16800 nM
The estimate for compound 3 lay 2.4-fold (0.38 log units) below the measured number; the range from low to high includes it.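

In this assay, chloro in place of fluoro on an aromatic carbon, para to a large group, gives a 1.7-fold higher number from compound 2 to compound 3 (0.24 log units; within the scatter), so this position does not separate the two substituents. With 4-chlorophenyl in place of 2-(trifluoromethyl)phenyl on the nitrogen, the series gives an at least 2.9-fold lower number from compound 1 to compound 3 (0.47 log units; beyond the scatter), which shows that the lower number obtained with 4-fluorophenyl is not unique to that group. The full size of this step cannot be read, since compound 1 gives only a limit: the limit of > 50000 nM in this assay, at which 1 of the 3 values shown sits.

Still open, as far as these compounds go, is whether methoxy, an amine or a carboxylic acid at this position would give a number beyond the scatter from those of compound 2 and compound 3. Also open, from the compounds shown here alone, is whether the weak result for compound 1 follows from the trifluoromethyl group itself or from where it sits, which a 4-(trifluoromethyl)phenyl group on the same nitrogen would address.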